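The source may report more compounds than this note shows. Statements on the series, on what has been measured and on what is new or still open speak of the compounds shown alone.

In an ADME assay on microsomes from liver (Mus musculus) for metabolic stability, read by LC-MS, using NADPH, with stated times of 15 min and 60 min, tested at 4.6 uM (on this read-out lower numbers stand for a shorter-lived compound and higher numbers for a longer-lived compound), compound 1 `CC(=O)N1CCC(c2ccc3c(c2)oc(=O)n3C(=O)NCCCCc2ccccc2)CC1` gives 1 h. Compound 2 `CC(C)CN1CCC(c2ccc3c(c2)oc(=O)n3C(=O)NCCCCc2ccccc2)CC1` gives 1 h, which places compound 2 level with compound 1 at the precision reported, and these two values are all there is to go on so far.

The next compound is compound 3 `CCN1CCN(c2ccc3c(c2)oc(=O)n3C(=O)NCCCCc2ccccc2)CC1`. It has 4-ethylpiperazin-1-yl in place of 1-isobutylpiperidin-4-yl on an aromatic carbon of the shared core: 4-ethylpiperazin-1-yl in place of 1-isobutylpiperidin-4-yl on an aromatic carbon.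

Among the compounds with values here, only one measured step bears on this change. Putting isobutyl in place of acetyl on an amine nitrogen in a ring gave no change at the digits printed from compound 1 to compound 2 (within the scatter). Within the data shown here, that step altered only the group on the ring nitrogen, and no measured pair tests an exchange of the ring itself, so the guidance is indirect.

The expectation therefore rests on compound 2 at 1 h and on that one step, and no shift beyond the scatter is expected in either direction in this assay. In numbers, the estimated move is no change at the digits printed from compound 2 to compound 3 (within the scatter). Compound 3 is expected to show 1 h, with an estimated range of 0.5 h to 2 h.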

Compound 3, half-life: < 0.0834 h
Compound 3: a limit, no number; the forecaster's own chance of this, stated with the estimate: 5%; middle value at least 11-fold (1.07 log units) away from the limit.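

The group on this aromatic carbon turns out to matter a great deal in this assay, whereas changing only the group on the ring nitrogen gave no change at the digits printed from compound 1 to compound 2 (within the scatter) and so gave no sign of this sensitivity. Putting 4-ethylpiperazin-1-yl in place of 1-isobutylpiperidin-4-yl gives an at least 11-fold lower number from compound 2 to compound 3 (1.07 log units; beyond the scatter) and putting it in place of 1-acetylpiperidin-4-yl gives an at least 11-fold lower number from compound 1 to compound 3 (1.07 log units; beyond the scatter) so the loss appears against both earlier groups and not against just one of them. The reading for compound 3 is a limit of the assay and not a number: the limit of < 0.0834 h in this assay, at which 1 of the 3 values shown sits.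

This exchange alters two things at once, since the ring goes from 1 hetero atom to 2 hetero atoms while the group on the ring nitrogen also becomes ethyl, and the compounds shown cannot tell which of these matters. On these data alone, a 1-ethylpiperidin-4-yl group would test the ethyl on its own and a 4-acetylpiperazin-1-yl group would test the second ring nitrogen on its own, so it remains open whether either would stay level with compound 1 or fall as far as compound 3.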